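Adding Fluoro to the Sulfonyl Aryl Group

The source may report more compounds than this note shows. Statements on the series, on what has been measured and on what is new or still open speak of the compounds shown alone.

Compound 3 `COc1ccc(-c2c(S(=O)(=O)c3ccc(F)cc3)cnc3c(F)cccc23)cc1` was tested in an ADME assay on microsomes from liver (Homo sapiens) for metabolic stability, tested at 2.5 uM (a higher number here means faster removal of the compound, a lower number slower removal), and gives 2.41 mL/min. Among the three measured compounds it stands second highest, close to compound 1 `COc1ccc(-c2c(S(=O)(=O)c3cc(F)cc(F)c3)cnc3c(F)cccc23)cc1`, which gives 2.59 mL/min, and further from compound 2 `O=S(=O)(c1ccc(F)c(F)c1)c1cnc2c(F)cccc2c1-c1cccc(F)c1`, which gives 1.28 mL/min, though both gaps lie within the scatter. Compound 4 `COc1ccc(-c2c(S(=O)(=O)c3ccc(F)c(F)c3)cnc3c(F)cccc23)cc1` differs from compound 3 by fluoro in place of hydrogen on an aromatic carbon. Among the measured compounds shown here, the one measured step that bears on this change, a change in the fluoro pattern on the same sulfonyl aryl group, was a 1.1-fold lower number from compound 1 to compound 3 (0.03 log units; within the scatter). Compound 2 carries the same 3,4-difluorophenyl but differs elsewhere as well, so its value alone cannot set the step. Compound 4 is therefore expected to move by a 1.1-fold lower number from compound 3 to compound 4 (0.04 log units; within the scatter), no more than the scatter, and its estimated value is 2.2 mL/min within 1.3 mL/min to 3.8 mL/min.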

Compound 4, intrinsic clearance in a liver preparation (reported as CLH), per the amount of preparation that the assay uses: 2.12 mL/min
Compound 4: the middle estimate sits 1.0-fold (0.02 log units) above what was measured; low and high end bracket the measured number.
By their numbers in this assay, from the lowest: compounds 2, 4, 3 and 1 (each within the scatter of the next, the first and the last beyond it).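

Adding a second fluoro to the 4-fluorophenyl, ortho to the fluoro group already there, leaves this assay within the scatter (a 1.1-fold lower number from compound 3 to compound 4 (0.06 log units; within the scatter)), and the 3,4-difluorophenyl of compound 4 cannot be told apart from the 3,5-difluorophenyl of compound 1 (a 1.2-fold lower number from compound 1 to compound 4 (0.09 log units; within the scatter)). The aryl group on the other side of the core, changed from 3-fluorophenyl to 4-methoxyphenyl, also stays within the scatter (a 1.7-fold higher number from compound 2 to compound 4 (0.22 log units; within the scatter)). No measured evidence accounts for these small steps. From the compounds shown here alone, whether an amine or a nitrile in place of this fluoro would shift removal beyond the scatter remains open.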